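Replacing isopropoxy with fluoro: how much activity remains?

The source may hold more compounds than are shown below. What is called first, only, known or untested is meant among the compounds shown, and "the series" means these compounds.

Among the measured compounds shown here, in a functional assay on HeLa cells (Homo sapiens) for antiproliferative activity, read by MTT assay, with a stated time of 72 h (a higher number here means a weaker inhibitor, a lower number a stronger inhibitor), compound 3 `COc1cc(-n2ncnc2-c2ccc(OC(C)C)cc2)cc(OC)c1OC` gives 600 nM as the only true number so far. Compound 1 `COc1cc(-n2ncnc2-c2ccc(Cl)cc2)cc(OC)c1OC` gives > 10000 nM here, which is a limit of the assay and not a number. Compound 2 `COc1cccc(-c2ncnn2-c2cc(OC)c(OC)c(OC)c2)c1` gives > 10000 nM here, which is again a limit. The change between these two is a step that the two limits leave unreadable from compound 1 to compound 2 and offers no guidance.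

Compound 4 `COc1cc(-n2ncnc2-c2ccc(F)cc2)cc(OC)c1OC` differs from compound 3 by fluoro in place of isopropoxy on an aromatic carbon, para to a large group (fluoro in place of isopropoxy on an aromatic carbon). The measured change that bears most directly on this is an at least 16-fold lower number from compound 1 to compound 3 (1.22 log units; beyond the scatter) when isopropoxy took the place of chloro. Compound 4 gives up that isopropoxy again, with fluoro where compound 1 has chloro, so a large change in the opposite direction is expected. The expected rise in the number is a 15-fold higher number from compound 3 to compound 4 (1.18 log units; beyond the scatter) and it would bring the result close to the limit of > 10000 nM in this assay, at which 2 of the 3 values shown sit, as its nearest reference. For compound 4 the estimated value is 9000 nM with an expected range from 2500 nM to 25000 nM in this assay.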

Compound 4, half-maximal inhibitory concentration: > 10000 nM
Compound 4 ended at the assay's limit (the forecaster's own chance of this, stated with the estimate: 65%); at least 1.1-fold (0.04 log units) between middle value and limit.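

In this assay, the result shows that the activity of compound 3 at this aromatic carbon, para to a large group, is lost with a second halogen and not just with chloro: fluoro in place of isopropoxy gives an at least 16-fold higher number from compound 3 to compound 4 (1.22 log units; beyond the scatter). Among the compounds that differ only here, isopropoxy is thus the one group that gives a true number, while chloro and fluoro do not. Compounds 1, 2 and 4 each give a limit of the assay and not a number, so the steps among them cannot be read: the limit of > 10000 nM in this assay, at which 3 of the 4 values shown sit.

Still open, going by these compounds, is whether the oxygen joined to the ring or the branched carbons behind it matter more, which a methoxy or an ethoxy group at this place would help to separate. Also open, on these data alone, is how an amine or a longer chain such as butoxy would fare here.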